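The source may hold more compounds than are shown below. What is called first, only, known or untested is meant among the compounds shown, and "the series" means these compounds.

Values in a functional assay on cells (Homo sapiens) for antiproliferative activity, read by sulforhodamine B assay, with a stated time of 48 h (a higher number here means a weaker inhibitor, a lower number a stronger inhibitor), are as follows.
- Compound 1 `CCCCCCCCCCNC(=O)[C@@H]1CSC(c2cc(OC)c(OC)c(OC)c2)N1` gives 14500 nM
- Compound 2 `CCCCCCCCCCCCCCNC(=O)[C@@H]1CSC(c2cc(OC)c(OC)c(OC)c2)N1` gives 2000 nM
- Compound 3 `CCCCCCCCCCCCCCCNC(=O)[C@@H]1CSC(c2ccc(NC(C)=O)cc2)N1` gives 1600 nM

Compound 3 sits within the scatter of compound 2, and both numbers lie under that of compound 1. Compound 4 `CCCCCCCCC/C=C\CCCCCCCNC(=O)[C@@H]1CSC(c2ccc(NC(C)=O)cc2)N1` differs from compound 3 in one place (a group of 11 heavy atoms (11 carbon; no ring) in place of a group of 8 heavy atoms (8 carbon; no ring), on a saturated chain carbon, seven bonds along the chain from an amide-type nitrogen). Among the compounds with values here, only one measured step bears on this (a 7.3-fold lower number from compound 1 to compound 2 (0.86 log units; beyond the scatter)). It was modest, and it was measured on a shorter chain with a different aromatic part. Within the data shown here, no measured step covers a double bond. In this assay a small downward step is therefore expected, possibly none beyond the scatter. The expected change (a 1.2-fold lower number from compound 3 to compound 4 (0.09 log units; within the scatter)) is slight. Compound 4 is estimated at 1300 nM within a range of 500 nM to 3500 nM as the expected span.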

Compound 4, half-maximal inhibitory concentration: 1400 nM
Estimate against measurement, compound 4: 1.1-fold (0.03 log units) below; low and high end bracket the measured number.
By their numbers in this assay, from the lowest: compounds 4, 3 and 2 (each within the scatter of the next); then compound 1.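

In this assay, octyl gives way to a larger group with a double bond, on a saturated chain carbon, seven bonds along the chain from an amide-type nitrogen, and the outcome is a 1.1-fold lower number from compound 3 to compound 4 (0.06 log units; within the scatter), with no shift beyond the scatter. The earlier compounds shown here did not show that this position accepts a larger group containing a double bond with the acetamide-bearing aromatic part retained. No evidence on hand bears on this result.

On these data alone, what the double bond contributes apart from chain size remains open, and a saturated chain of the same length would address this. Also open, as far as these compounds go, is how a terminal amine or carboxylic acid on the chain would read out.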